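Methyl to difluoro: a cytotoxicity step estimated

The source may hold more compounds than are shown below. What is called first, only, known or untested is meant among the compounds shown, and "the series" means these compounds.

Compound 2 `CCOC(=O)c1cc(-c2cccc(OCc3cccc(C)c3)c2)on1` carries a 3-methylphenyl group on the chain that links to the shared core. In an ADME assay on Vero cells (Chlorocebus sabaeus) for cytotoxicity, with a stated time of 72 h (on this read-out higher numbers stand for weaker inhibition and lower numbers for stronger inhibition), compound 2 gives only a limit, > 128000 nM. Among the compounds with values here, its one measured neighbour, compound 1 `CCOC(=O)c1cc(-c2cccc(OCc3cccc(Br)c3)c2)on1`, differs by bromo where compound 2 has methyl. In this assay compound 1 likewise reaches only a limit, > 128000 nM. The step from the bromo compound to the methyl compound is a step that the two limits leave unreadable from compound 1 to compound 2, since both values sit at the limit of > 128000 nM in this assay, at which 2 of the 2 values shown sit. Compound 3 `CCOC(=O)c1cc(-c2cccc(OCc3cccc(F)c3F)c2)on1` has not yet been measured. The change is 2,3-difluorophenyl in place of 3-methylphenyl on a saturated chain carbon bound to an oxygen on an aromatic ring. Within the data shown here, the single measured step that bears on it cannot be read in size, so no movement beyond the scatter is expected in either direction. The step from compound 2 to compound 3 is expected to be a step that the limit leaves unreadable from compound 2 to compound 3. Compound 3 is estimated to give 200000 nM, with a range from 100000 nM to 500000 nM, and most likely again only a limit.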

Compound 3, half-maximal inhibitory concentration: > 128000 nM
Compound 3: a limit, no number (the forecaster's own chance of this, stated with the estimate: 85%); the middle value lies beyond the limit too.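

In this assay, within the data shown here, compound 1, compound 2 and compound 3 each reach only a limit, so no step among them can be read in size. The compounds shown leave open at what concentration any of the three would inhibit the cells, and whether their groups differ at all.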